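The compounds below may be only part of what the source reports. "The series", "measured", "known", "first", "only" and "open" are said of these compounds alone.

Measured so far:
compound 1 `COC1CN(C(=O)/C=C/c2ccncc2-c2ccc3ccccc3c2)C1`: > 30000 nM
compound 2 `O=C(O)[C@@H]1CCCN1C(=O)/C=C/c1ccncc1-c1ccc2ccccc2c1`: "not determined" (no result reported)

In a functional assay on HCT-116 cells (Homo sapiens) for inhibition, read by MTT assay, with a stated time of 72 h (on this read-out lower numbers stand for stronger inhibition of growth and higher numbers for weaker inhibition of growth), compound 1 gives only a limit, > 30000 nM. Among the compounds with values here, compound 2 stands without a number in this assay; the one further value shown is a limit (the limit of > 30000 nM in this assay, at which 1 of the 2 values shown sits). Compound 3 `CN1CCN(C(=O)/C=C/c2ccncc2-c2ccc3ccccc3c2)CC1` differs from compound 2 by 4-methylpiperazin-1-yl in place of 2-carboxypyrrolidin-1-yl on a carbonyl carbon. Within the data shown here, no step between measured compounds exists here, so no step beyond the scatter is expected in this assay in either direction. Compound 3 is expected to give 30000 nM, estimated between 10000 nM and 100000 nM, most likely again as a limit.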

Compound 3, concentration for 50% growth inhibition: > 30000 nM
Compound 3 ended at the assay's limit; the forecaster's own chance of this, stated with the estimate: 70%; the middle value sits exactly at the limit.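

In this assay, within the data shown here, compound 1 and compound 3 both stand only as limits, so no step between them can be read: the limit of > 30000 nM in this assay, at which 2 of the 3 values shown sit.

The compounds shown leave open whether any group on this carbonyl carbon gives a measurable growth inhibition value.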